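Replacing the pyrazolyl amide of compound 3 with a larger group

The compounds below may be only part of what the source reports. "The series", "measured", "known", "first", "only" and "open" are said of these compounds alone.

Measured compounds:
compound 1, `CCOC(=O)C1=C(C)NC(C)=C(C(=O)OCC)C1c1ccc(OCC(=O)Nc2ccc(C)cc2)cc1`, 43.9%
compound 2, `CCOC(=O)C1=C(C)NC(C)=C(C(=O)OCC)C1c1ccc(OCC(=O)NNC(=O)c2sccc2Cl)cc1`, 10.6%
compound 3, `CCOC(=O)C1=C(C)NC(C)=C(C(=O)OCC)C1c1ccc(OCC(=O)n2nc(C)cc2C)cc1`, 13.7%

In a functional assay on the whole organism (strain Wistar) for inhibition, with Rattus norvegicus as the target, read by paw edema, with stated times of 30 min and 0.5 h, at a dose of 20 mg/kg (a higher number here means more inhibition at the dose given (going by the name of the read-out), a lower number less inhibition), compound 1 gives 43.9%. Compound 2 gives 10.6%, and compound 3 gives 13.7%. Among these three numbers compound 3 stands second highest; its nearest neighbour is compound 2, and the gap a number 3.1 percentage points higher from compound 2 to compound 3 (within the scatter) lies within the scatter, while the gap to compound 1, a number 30.2 percentage points lower from compound 1 to compound 3 (beyond the scatter), lies well beyond it.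

Compound 4, `CCOC(=O)C1=C(C)NC(C)=C(C(=O)OCC)C1c1ccc(OCC(=O)NN2C(=O)c3ccccc3C2=O)cc1`, has not yet been measured. It differs from compound 3 in one place: a group of 12 heavy atoms (8 carbon, 2 nitrogen, 2 oxygen; one five-membered non-aromatic ring with 1 hetero atom, one six-membered aromatic ring of carbon only) in place of a group of 7 heavy atoms (5 carbon, 2 nitrogen; one five-membered aromatic ring with 2 hetero atoms), on a carbonyl carbon.

Going by the values given here, two measured steps bear on this change. Both replacements of the (4-methylphenyl)amino group on the carbonyl carbon were large and downward, a number 33.3 percentage points lower from compound 1 to compound 2 (beyond the scatter) and a number 30.2 percentage points lower from compound 1 to compound 3 (beyond the scatter), whereas the exchange between the two non-anilide groups, a number 3.1 percentage points higher from compound 2 to compound 3 (within the scatter), stayed within the scatter. Compound 4 carries a third group of this kind on the same carbonyl carbon, so the step is expected to be small, a number 0.3 percentage points higher from compound 3 to compound 4 (within the scatter), with no clear direction. For compound 4 the inhibition is estimated at 14%, with a range from 4% to 30%.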

Compound 4, a percentage reported as inhibition, in the whole organism at one dose (the size of the read-out at that dose, not a potency): 34.1%
Compound 4: the middle estimate sits 20.1 percentage points below what was measured, and the stated range ends below it.
By their numbers in this assay, from the lowest: compounds 2 and 3 (each within the scatter of the next); then compounds 4 and 1 (each within the scatter of the next).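

Replacing the 3,5-dimethyl-1H-pyrazol-1-yl group on the carbonyl carbon with the group holding a five-membered non-aromatic ring and a six-membered aromatic ring gave a number 20.4 percentage points higher from compound 3 to compound 4 (beyond the scatter) in this assay. On the amide-type nitrogen, the same ring group in place of the ((3-chlorothiophen-2-yl)carbonyl)amino group gave a number 23.5 percentage points higher from compound 2 to compound 4 (beyond the scatter). Losing the 4-methylphenyl group therefore does not in itself bring the low numbers, as the step of a number 9.8 percentage points lower from compound 1 to compound 4 (within the scatter) shows, so the replacements at this position do not all behave alike.

Nothing shown here explains why this ring group differs from the other two replacements. On these data alone, it also remains open whether a morpholine or a plain amino group on the same carbonyl carbon would match compound 1 and compound 4 or compound 2 and compound 3.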